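The source may hold more compounds than are shown below. What is called first, only, known or untested is meant among the compounds shown, and "the series" means these compounds.

Compound 1 `CC(C)c1noc(N2CCN(C(=O)[C@@H]3CCCN(S(=O)(=O)c4ccc(S(=O)(=O)C(C)C)cc4)C3)CC2)n1`, compound 2 `CCN(CC)S(=O)(=O)c1ccc(S(=O)(=O)N2CCC[C@@H](C(=O)N[C@@H]3CCN(C(=O)OC(C)(C)C)C3)C2)cc1` and compound 3 `CCN(CC)S(=O)(=O)c1ccc(S(=O)(=O)N2CCC[C@@H](C(=O)NC3CN(C(=O)C4CC4)C3)C2)cc1` share one core and differ only at the amide end. In a functional assay on MIA PaCa-2 cells (Homo sapiens) for inhibition, read by MTT assay, with a stated time of 3 days (a higher number here means a weaker inhibitor, a lower number a stronger inhibitor), compound 1 reaches only a limit, > 10000 nM. Compound 2 likewise gives only a limit in this assay, > 10000 nM. Compound 3 also stands at a limit in this assay, > 10000 nM, so it cannot be ranked against the other two. Within the data shown here, the single one-point step, a step that the two limits leave unreadable from compound 2 to compound 3, therefore has no readable size, and the only evidence is the limit of > 10000 nM in this assay, at which 3 of the 3 values shown sit. Compound 4 `CCN(CC)C(=O)[C@@H]1CCCN(S(=O)(=O)c2ccc(S(=O)(=O)N(CC)CC)cc2)C1` differs from compound 3 by diethylamino in place of (1-(cyclopropylcarbonyl)azetidin-3-yl)amino on a carbonyl carbon. Among the measured compounds shown here, no measured step offers a readable size, so the step that the limit leaves unreadable from compound 3 to compound 4 is expected to leave compound 4 at the same limit. Compound 4 is estimated at 20000 nM, within 5000 nM to 100000 nM.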

Compound 4, half-maximal inhibitory concentration: > 10000 nM
Compound 4 ended at the assay's limit; the forecaster's own chance of this, stated with the estimate: 85%; the middle value is on the limit's open side.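

Compound 4, like compound 3, stands only at a limit in this assay, so no step can be read between these two compounds. What the compounds shown leave open is how any change at the amide end bears on inhibition: the limit of > 10000 nM in this assay, at which 4 of the 4 values shown sit.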